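Aryl-for-cyclohexyl exchange: expected cytotoxicity of compound 3

This account rests on a few compounds, and the source may have more. Where it says the series, first, only, none or still open, it means among the compounds named here.

Measured in an ADME assay on HepG2 cells (Homo sapiens) for cytotoxicity, read by luminescence, CellTiter-Glo and ATP content, with a stated time of 72 h; on this read-out lower numbers stand for an effect already at smaller amounts and higher numbers for an effect only at larger amounts of compound:
Compound 1 `COc1ccc(-c2ccc3c(NCCCNCc4cccc(OC)c4O)ccnc3c2)cc1`: 1600 nM
Compound 2 `COc1cccc(CNCCCNc2ccnc3cc(C4CCCCC4)ccc23)c1O`: 1080 nM

Compound 2 gives the lowest of the two numbers, with compound 1 nearest to it, and the step of a 1.5-fold lower number from compound 1 to compound 2 (0.17 log units; within the scatter) is within the scatter. Compound 3 `COc1cccc(CNCCCNc2ccnc3cc(-c4ccc(F)cc4)ccc23)c1O` differs from compound 2 by 4-fluorophenyl in place of cyclohexyl on an aromatic carbon. Within the data shown here, the only measured step, a 1.5-fold lower number from compound 1 to compound 2 (0.17 log units; within the scatter), exchanged one six-membered ring for another at the same aromatic carbon and stayed within the scatter; compound 1 and compound 3 both carry an aromatic ring there. No step beyond the scatter is therefore expected in this assay. The expected step is a 1.2-fold higher number from compound 2 to compound 3 (0.08 log units; within the scatter). Compound 3 is estimated at 1300 nM, range 600 nM to 2800 nM.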

Compound 3, half-maximal effective concentration: 6840 nM
The estimate for compound 3 lay 5.3-fold (0.72 log units) below the measured number; measured number above the stated range.
By their numbers in this assay, from the lowest: compounds 2 and 1 (each within the scatter of the next); then compound 3.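

In this assay the substituent on the aryl ring at this position matters: fluoro in place of methoxy gives a 4.3-fold higher number from compound 1 to compound 3 (0.63 log units; beyond the scatter) and 4-fluorophenyl in place of cyclohexyl gives a 6.3-fold higher number from compound 2 to compound 3 (0.80 log units; beyond the scatter) on the same aromatic carbon. An aromatic ring there does not alone set the number, as compound 1 and compound 2 lie within the scatter of each other. Nothing available explains the difference.

As far as these compounds go, whether the higher number follows from fluoro itself or from the loss of methoxy remains open. Unsubstituted phenyl, or an amine on that ring, could separate the two.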